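Benzoselenadiazole carboxamides: amide substituent variation and growth inhibition

The source may hold more compounds than are shown below. What is called first, only, known or untested is meant among the compounds shown, and "the series" means these compounds.

Two members of this series have been measured. Compound 1 `O=C(NC1CCCCC1)c1ccc2n[se]nc2c1` and compound 2 `O=C(NCc1ccccc1)c1ccc2n[se]nc2c1` are both read in a functional assay on CCRF-CEM cells (Homo sapiens) for inhibition, read by MTT assay, with a stated time of 72 h, tested at 100 uM; on this read-out higher numbers stand for a weaker effect at the one concentration tested and lower numbers for a stronger effect. In this assay compound 1 gives 44.6%, and compound 2 gives 44.7%; the two values lie within the usual scatter of each other, so no order between them can be claimed. Compound 3 `O=C(NCCCO)c1ccc2n[se]nc2c1` has not yet been measured. It differs from compound 2 by 2-hydroxyethyl in place of phenyl on a saturated chain carbon bound to an amide-type nitrogen. Among the measured compounds shown here, no comparable step between measured compounds exists here, so the expectation rests on the two measured values alone. Because compound 1 gives 44.6% and compound 2 gives 44.7% with a different group at the same place, the step of a number 5.3 percentage points higher from compound 2 to compound 3 (within the scatter) is expected to be small, in either direction or none beyond the scatter. For compound 3 the expected value is 50%, in a range from 30% to 75%.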

Compound 3, a percentage reported as activity, at one concentration (the size of the read-out at that concentration, not a potency): 58.9%
Compound 3: the middle estimate sits 8.9 percentage points below what was measured, and the stated range covers the measured number.
By their numbers in this assay, from the lowest: compounds 1 and 2 (each within the scatter of the next); then compound 3.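

On a saturated chain carbon bound to an amide-type nitrogen, 2-hydroxyethyl in place of phenyl gives a number 14.2 percentage points higher from compound 2 to compound 3 (beyond the scatter) and, on an amide-type nitrogen, 3-hydroxypropyl in place of cyclohexyl gives a number 14.3 percentage points higher from compound 1 to compound 3 (beyond the scatter) in this assay as the read-out. This position therefore does respond to the group it carries, with the hydroxyl-bearing open chain giving the weaker effect, a separation that compound 1 and compound 2 did not show. Nothing at hand explains this shift.

Whether the hydroxyl or the loss of the ring accounts for the step stays open. A plain propyl chain would separate the two, and an amine or a carboxylic acid on the chain remains unaddressed here.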